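Compound 1 to compound 4: changing the nitrogen substituent

The compounds below may be only part of what the source reports. "The series", "measured", "known", "first", "only" and "open" are said of these compounds alone.

In a functional assay on HCT-116 cells (Homo sapiens) for antiproliferative activity, read by MTT assay, with a stated time of 48 h (a higher number here means a weaker inhibitor, a lower number a stronger inhibitor), compound 1 (`COc1cccc(-n2cc(COc3ccc(/C=C/C(C)=O)cc3OC)nn2)c1`) gives 29600 nM. Compound 2 (`COc1cc(/C=C/C(C)=O)ccc1OCc1cn(-c2ccc(C(F)(F)F)c(C(F)(F)F)c2)nn1`) gives 57800 nM, within the scatter of compound 1. Compound 3 (`CCOC(=O)c1ccc(-n2cc(COc3ccc(/C=C/C(C)=O)cc3OC)nn2)cc1`) gives 78900 nM, a higher number than compound 1 and beyond the scatter. Compound 4 (`COc1cc(/C=C/C(C)=O)ccc1OCc1cn(-c2ccccc2Cl)nn1`) has 2-chlorophenyl in place of 3-methoxyphenyl on an aromatic nitrogen. Going by the values given here, no measured pair isolates this change, so the expectation rests on the narrow spread of the three values in this assay. The estimated step of a 1.4-fold higher number from compound 1 to compound 4 (0.13 log units; within the scatter) is expected to point towards a slightly higher number, with no change beyond the scatter. Compound 4 is estimated at 40000 nM, with an expected range of 15000 nM to 100000 nM.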

Compound 4, half-maximal inhibitory concentration: 39000 nM
For compound 4 the middle estimate is 1.0-fold (0.01 log units) above the measured one; the range from low to high includes it.
By their numbers in this assay, from the lowest: compounds 1, 4, 2 and 3 (each within the scatter of the next, the first and the last beyond it).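

In this assay the exchange of 3-methoxyphenyl for 2-chlorophenyl on the aromatic nitrogen gives a 1.3-fold higher number from compound 1 to compound 4 (0.12 log units; within the scatter) and is the only single-change step shown at this position. A chlorine-bearing ring in place of a methoxy-bearing one, with one hydrogen-bond acceptor fewer in the group, leaves the reading within the scatter. No measurement available here bears on this result.

Open, from the compounds shown here alone, is how the position responds to a group other than a substituted phenyl, such as a longer alkyl chain. A phenyl carrying an amine or a carboxylic acid also remains to be read against compound 1.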